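The source may hold more compounds than are shown below. What is called first, only, known or untested is meant among the compounds shown, and "the series" means these compounds.

For the measured compounds named here, four compounds belong to this account, and only two of them have numbers so far. In an ADME assay on L6 cells (Rattus norvegicus) for cytotoxicity (on this read-out higher numbers stand for weaker inhibition and lower numbers for stronger inhibition), compound 1 (`CN(C)C12CC(O)C(C(c3ccccc3)C1)C(c1ccccc1)C2`) gives 133000 nM and compound 3 (`CN(C)C12C/C(=N\O)C(C(c3ccccc3)C1)C(c1ccccc1)C2`) gives 150000 nM on the same read-out. These two values lie within the usual scatter of each other, so compound 3 stands level with compound 1, and no order can be drawn between them. Compound 2 (`COc1ccc(C2CC3(N4CCCCC4)CC(=O)C2C(c2ccc(OC)cc2)C3)cc1`) offers no further comparison, its entry in this assay reading "not determined" (no result reported) for that compound.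

The open case is compound 4 (`O/N=C1\CC2(N3CCCC3)CC(c3ccccc3)C1C(c1ccccc1)C2`), which differs from compound 3 in one place: pyrrolidin-1-yl in place of dimethylamino on a saturated ring carbon. Going by the values given here, no measured pair shows this change, so the data offer no direct precedent for its size. The expectation therefore starts from compound 3 at 150000 nM and allows for real uncertainty in either direction. In this assay the expected change is no step beyond the scatter, with only a slight lean toward a lower number. The estimated step is a 1.4-fold lower number from compound 3 to compound 4 (0.13 log units; within the scatter) on this reading. For compound 4 the expected value is 110000 nM (estimated range 40000 nM to 220000 nM).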

Compound 4, half-maximal inhibitory concentration: 13500 nM
For compound 4 the middle estimate is 8.1-fold (0.91 log units) above the measured one, outside the stated range (below it).
By their numbers in this assay, from the lowest: compound 4; then compounds 1 and 3 (each within the scatter of the next).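

For the compounds shown here, exchanging dimethylamino for pyrrolidin-1-yl on the saturated ring carbon gives an 11-fold lower number from compound 3 to compound 4 (1.05 log units; beyond the scatter) in this assay, the only step read so far and a large one. The two earlier values stood within the scatter of each other and gave no sign that the read-out could move this far, whereas this pair shows that the group on this carbon alone can shift it well beyond the scatter. No measurement at hand bears on why this exchange has so large an effect.

The change is read only once, on the core of compound 3, so the compounds shown do not tell whether it would carry over to a core with another group in the place of the shared ring substituents, as in compound 1. They also leave open whether the shift follows from closing the two carbon chains on the nitrogen into a ring or from the added carbon atoms, a question that a diethylamino or a morpholin-4-yl group on the same saturated ring carbon would help to settle.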